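The source may report more compounds than this note shows. Statements on the series, on what has been measured and on what is new or still open speak of the compounds shown alone.

Of the compounds shown here, three built on a shared core have been measured in a functional assay on DU-145 cells (Homo sapiens) for inhibition, read by trypan blue exclusion, with a stated time of 72 h; on this read-out higher numbers stand for weaker inhibition and lower numbers for stronger inhibition. Compound 1 `Cn1c(=O)c(S(=O)(=O)c2ccccc2)cc2cnc(Nc3ccc4cc[nH]c4c3)nc21` gives 10000 nM, compound 2 `Cn1c(=O)c(S(=O)(=O)c2ccc([N+](=O)[O-])cc2F)cc2cnc(Nc3ccc4[nH]ccc4c3)nc21` gives 400 nM, and compound 3 `Cn1c(=O)c(S(=O)(=O)c2ccc(F)cc2F)cc2cnc(Nc3ccc4sccc4c3)nc21` gives 500 nM. Compound 2 holds the lowest number of the three; its gap to compound 3 lies within the scatter, while its gap to compound 1 lies beyond it. Compound 4 `Cn1c(=O)c(S(=O)(=O)Nc2ccc(F)cc2)cc2cnc(Nc3ccc4[nH]ccc4c3)nc21` has not been measured and differs from compound 2 in one place: (4-fluorophenyl)amino in place of 2-fluoro-4-nitrophenyl on a sulfonyl sulfur. Among the compounds with values here, no measured pair shows this kind of change, so the expectation rests on little. The expected step is a 3.8-fold higher number from compound 2 to compound 4 (0.57 log units; beyond the scatter), toward weaker inhibition, with wide uncertainty. Compound 4 is estimated at 1500 nM, in a range from 300 nM to 8000 nM in this assay.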

Compound 4, half-maximal inhibitory concentration: 5000 nM
For compound 4 the middle estimate is 3.3-fold (0.52 log units) below the measured one; low and high end bracket the measured number.
By their numbers in this assay, from the lowest: compounds 2 and 3 (each within the scatter of the next); then compounds 4 and 1 (each within the scatter of the next).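

In this assay, the group on the sulfonyl sulfur clearly matters: (4-fluorophenyl)amino in place of 2-fluoro-4-nitrophenyl gives a 13-fold higher number from compound 2 to compound 4 (1.10 log units; beyond the scatter), the first single-place step seen at this position. This one step combines the new amino link to the sulfur with the loss of the nitro group, so it cannot be assigned to either change alone. Nothing measured here bears on why the number rises. Still open, from the compounds shown here alone, is whether 2-fluoro-4-nitrophenyl attached through the same amino link, or a morpholine on the sulfur, would read closer to compound 2 or compound 4.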